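Swapping a nitrophenyl amide for a cyclobutyl amide

The source may report more compounds than this note shows. Statements on the series, on what has been measured and on what is new or still open speak of the compounds shown alone.

Three compounds share a core and were tested in an assay on isolated protein for inhibition of aldehyde dehydrogenase 1A1 (Homo sapiens), read by spectrophotometry, tested at 10 uM; a higher number here means more inhibition at the concentration tested (going by the name of the read-out), a lower number less inhibition. Compound 1 `Cc1cccc(Cn2c(CN3CCN(C(=O)c4ccc([N+](=O)[O-])cc4)CC3)nc3ccccc32)c1` gives 24.3%. Compound 2 `CCn1c(CN2CCN(C(=O)C3CC3)CC2)nc2ccccc21` gives 20.8%, and compound 3 `CC(C)CCn1c(OC2CCN(C(=O)c3ccco3)CC2)nc2ccccc21` gives 30.8%; both numbers lie within the usual scatter of compound 1, so the three read as alike. Compound 4 `Cc1cccc(Cn2c(CN3CCN(C(=O)C4CCC4)CC3)nc3ccccc32)c1` has not been measured. It differs from compound 1 in one place: cyclobutyl in place of 4-nitrophenyl on a carbonyl carbon. Within the data shown here, no measured pair shows this change directly, yet compound 2 carries a small carbon ring on its carbonyl and gives 20.8%. The step is therefore expected to stay within the scatter, with a number 2.3 percentage points lower from compound 1 to compound 4 (within the scatter) estimated. Compound 4 is expected to give about 22%, in the range 10% to 35%.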

Compound 4, a percentage reported as inhibition, at one concentration (the size of the read-out at that concentration, not a potency): 69.1%
For compound 4 the middle estimate is 47.1 percentage points below the measured one; measured number above the stated range.
By their numbers in this assay, from the lowest: compounds 2, 1 and 3 (each within the scatter of the next); then compound 4.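

Cyclobutyl in place of 4-nitrophenyl on a carbonyl carbon gives a number 44.8 percentage points higher from compound 1 to compound 4 (beyond the scatter) in this assay, so this one position can move the number strongly while the rest of compound 1 stays unchanged. The earlier compounds shown here differ in several places at once and could not isolate this position. No measurement here accounts for the rise.

Still open, from the compounds shown here alone, is whether cyclopentyl or an unsubstituted phenyl on the same carbonyl would behave like cyclobutyl or like 4-nitrophenyl. Also open, going by these compounds, is whether the same swap would raise the number on a different shared-core compound.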